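A few compounds are considered here, and "the series" means these few. Any claim that something is new, unique, unknown or untested is made for them only; others in the source may bear on it.

In a functional assay on KYSE-70 cells for antiproliferative activity against KYSE-70 cell line (Homo sapiens), read by MTT assay, with a stated time of 72 h (a lower number here means a stronger inhibitor, a higher number a weaker inhibitor), compound 1 `O=C(Nc1cccc(F)c1)c1cc(=O)[nH]c2cc(F)ccc12` shows > 20000 nM, which is a limit of the assay and not a number. Among the compounds with values here, compound 2 `O=C(Nc1cccc(F)c1)c1cc(=O)[nH]c2cc(C3=CCOCC3)ccc12` gives 10500 nM, the only true number so far. Its standing can be judged against the limit of compound 1 alone. Within the data shown here, the one measured step acts on the same aromatic carbon that changes next: a six-membered non-aromatic ring group replaced a fluorine atom and gave an at least 1.9-fold lower number from compound 1 to compound 2 (0.27 log units; that floor lies within the scatter). On these data alone, the real size of that step stays open because of the limit of > 20000 nM in this assay, at which 1 of the 2 values shown sits. It therefore offers only weak guidance, though it does show that a larger group at this carbon can keep a measurable value. Compound 3 `Cc1cc(-c2ccc3c(C(=O)Nc4cccc(F)c4)cc(=O)[nH]c3c2)c(C)cc1F` changes the same carbon again, with 4-fluoro-2,5-dimethylphenyl entering: a group of 9 heavy atoms (8 carbon, 1 fluorine; one six-membered aromatic ring of carbon only) in place of a group of 6 heavy atoms (5 carbon, 1 oxygen; one six-membered non-aromatic ring with 1 hetero atom), on an aromatic carbon. With so little evidence, only a modest move toward a lower number is expected in this assay, probably not clearly beyond the scatter. The estimated change is a 1.8-fold lower number from compound 2 to compound 3 (0.24 log units; within the scatter). For compound 3 the expected value is 6000 nM, with an estimated range from 1500 nM to 20000 nM.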

Compound 3, half-maximal inhibitory concentration: > 20000 nM
Compound 3: a limit, no number; the forecaster's own chance of this, stated with the estimate: 20%; at least 3.3-fold (0.52 log units) between middle value and limit.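

In this assay, compound 3 gives > 20000 nM, which is a limit of the assay and not a number. Putting 4-fluoro-2,5-dimethylphenyl on this aromatic carbon, in place of the six-membered non-aromatic ring of compound 2, gives an at least 1.9-fold higher number from compound 2 to compound 3 (0.27 log units; that floor lies within the scatter), so a measurable value here does not come with every group larger than fluorine, although that floor alone does not separate the two compounds beyond the scatter. The step between compound 1 and compound 3 cannot be read, and the true size of the step from compound 2 stays open because of this ceiling on the read-out: the limit of > 20000 nM in this assay, at which 2 of the 3 values shown sit.

The compounds shown leave open whether the loss of a measurable value belongs to the aromatic ring itself or to its fluorine and two methyl groups, and whether the oxygen in the ring of compound 2 matters at all. An unsubstituted phenyl ring, a morpholine amine or a carboxylic acid on this same carbon would each bear on those questions, and any of them might reach a value well clear of the limit.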